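A few compounds are considered here, and "the series" means these few. Any claim that something is new, unique, unknown or untested is made for them only; others in the source may bear on it.

Three compounds share one core and differ at two positions. Compound 1 `Clc1ccc(CO/N=C/c2c(-c3ccc4ccccc4c3)nc3sccn23)cc1Cl` is the most potent of the three: in an assay on HepG2 cells for agonist activity at nuclear receptor subfamily 1 group I member 3 (Homo sapiens), read by a luciferase reporter, with a stated time of 23 h (on this read-out lower numbers stand for an effect already at smaller amounts and higher numbers for an effect only at larger amounts of compound), compound 1 gives 380 nM. Compound 3 `Clc1ccc(CO/N=C/c2c(-c3ccc4ccccc4c3)nc3occn23)cc1` gives 990 nM in this assay, and compound 2 `CC(C)(C)c1ccc(CO/N=C/c2c(-c3ccc4ccccc4c3)nc3occn23)cc1` gives 7900 nM. For the measured compounds named here, the only step between two compounds that differ in one place is an 8.0-fold lower number from compound 2 to compound 3 (0.90 log units; beyond the scatter), a change at a position other than the one that matters here. Compound 4 `Fc1ccc(-c2nc3sccn3c2/C=N/OCc2ccc(Cl)c(Cl)c2)cc1` has not yet been measured in this assay. It differs from compound 1 in a single place: 4-fluorophenyl in place of naphthalen-2-yl on an aromatic carbon. Going by the values given here, no measured step touches this part of the structure; the step from compound 2 to compound 3 concerns a different position, so its size gives no direct guidance, and the direction of the change is uncertain. The number for compound 4 is nevertheless expected to move somewhat upward from that of compound 1, by a 3.2-fold higher number from compound 1 to compound 4 (0.50 log units; beyond the scatter). Compound 4 is therefore estimated to give 1200 nM in this assay, within a range from 300 nM to 5000 nM.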

Compound 4, half-maximal effective concentration: 670 nM
The estimate for compound 4 lay 1.8-fold (0.25 log units) above the measured number, and the stated range covers the measured number.
By their numbers in this assay, from the lowest: compounds 1, 4 and 3 (each within the scatter of the next, the first and the last beyond it); then compound 2.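

In this assay, the swap at this position gives a 1.8-fold higher number from compound 1 to compound 4 (0.25 log units; within the scatter). For the compounds shown here, the step is the first reading at this aromatic carbon, and it shows that 4-fluorophenyl, with one six-membered aromatic ring, and naphthalen-2-yl, with two, cannot be told apart here, so the second ring of naphthalen-2-yl is not required for a number of this size on the core of compound 1. No measurement bears on why the two groups read alike.

As far as these compounds go, whether the fluorine of 4-fluorophenyl matters remains open, as a plain phenyl would be needed to judge it, and so does the response to a group of another kind here, such as an amine or a carboxylic acid. From the compounds shown here alone, it is also open whether 4-fluorophenyl and naphthalen-2-yl would read alike on the core of compound 3.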